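Replacing a Long Side Chain with a Shorter One

The compounds below may be only part of what the source reports. "The series", "measured", "known", "first", "only" and "open" are said of these compounds alone.

In a functional assay for inhibition, with Homo sapiens as the target (on this read-out higher numbers stand for weaker inhibition and lower numbers for stronger inhibition), compound 1 `CC(C)(C)Sc1c(CC(C)(C)C(=O)O)n(Cc2ccc(Cl)cc2)c2ccc(CCc3ccc4ccccc4n3)cc12` gives 4 nM, and compound 2 `CC(C)(C)Sc1c(CC(C)(C)C(=O)O)n(Cc2ccc(Cl)cc2)c2ccc(OCc3ccc4cnccc4n3)cc12` gives 3 nM; the two numbers sit within the scatter of each other. Going by the values given here, the only measured step, a 1.3-fold lower number from compound 1 to compound 2 (0.12 log units; within the scatter), swapped one group for another of equal size and left the number unchanged. Compound 3 `CC(C)(C)Sc1c(CC(C)(C)C(=O)O)n(Cc2ccc(Cl)cc2)c2ccc(OCc3cccs3)cc12` differs from compound 1 by (thiophen-2-yl)methoxy in place of 2-(quinolin-2-yl)ethyl on an aromatic carbon. Among the compounds with values here, no measured step covers a shortening of this kind, so that step gives little guidance; a modestly weaker number is expected, a 3.8-fold higher number from compound 1 to compound 3 (0.57 log units; beyond the scatter). Compound 3 is therefore estimated at 15 nM, within 4 nM to 60 nM.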

Compound 3, half-maximal inhibitory concentration: 4 nM
Compound 3: the middle estimate sits 3.8-fold (0.57 log units) above what was measured; measured number inside the range.
By their numbers in this assay, from the lowest: compounds 2, 1 and 3 (each within the scatter of the next).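

In this assay, (thiophen-2-yl)methoxy in place of 2-(quinolin-2-yl)ethyl gives no change at the digits printed from compound 1 to compound 3 (within the scatter), and the exchange of the group on the oxygen gives a 1.3-fold higher number from compound 2 to compound 3 (0.12 log units; within the scatter). At this position, then, (thiophen-2-yl)methoxy holds the number as well as 2-(quinolin-2-yl)ethyl. Nothing available explains this result. Still open, going by these compounds, is whether the number holds with a bare methoxy, or with an amine or a carboxylic acid in place of the thiophene ring.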